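Taking the (1-Bromoethenyl)carbonyl Off Compound 2

The source may report more compounds than this note shows. Statements on the series, on what has been measured and on what is new or still open speak of the compounds shown alone.

Compound 2 `C=C(Br)C(=O)Nc1cccc(/C=C2\SC(=O)N(Cc3ccc(F)cc3)C2=O)c1` gives the lowest of the two numbers measured in a functional assay on CCRF-CEM cells (Homo sapiens) for cytotoxicity, read by cell counting, with a stated time of 3 days (on this read-out higher numbers stand for weaker inhibition and lower numbers for stronger inhibition), at 680 nM, while compound 1 `CC(C)(C)c1ccc(CN2C(=O)S/C(=C\c3cccc(N)c3)C2=O)cc1` gives 165000 nM, a gap well beyond the scatter. Compound 3 `Nc1cccc(/C=C2\SC(=O)N(Cc3ccc(F)cc3)C2=O)c1` differs from compound 2 in one place: hydrogen in place of (1-bromoethenyl)carbonyl on a nitrogen on an aromatic ring. Within the data shown here, no measured step of this kind exists here, so the expectation rests on compound 1, which also carries a free amino group and gives 165000 nM. A large rise, far beyond the scatter, is expected for the step of a 150-fold higher number from compound 2 to compound 3 (2.17 log units; beyond the scatter). Compound 3 is therefore estimated at 100000 nM, within a range of 20000 nM to 300000 nM.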

Compound 3, half-maximal inhibitory concentration: 87000 nM
Beside the measured number, compound 3's estimate is 1.1-fold (0.06 log units) above it; measured number inside the range.
By their numbers in this assay, from the lowest: compound 2; then compounds 3 and 1 (each within the scatter of the next).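

In this assay, hydrogen in place of (1-bromoethenyl)carbonyl on the aromatic amine nitrogen gives a 130-fold higher number from compound 2 to compound 3 (2.11 log units; beyond the scatter) as a single change, which ties the large gap to this group. Fluoro in place of tert-butyl on an aromatic carbon gives a 1.9-fold lower number from compound 1 to compound 3 (0.28 log units; within the scatter) and so leaves the two free amines indistinguishable. The compounds shown leave open whether the bromine, the double bond or the amide carbonyl matters, which an acetyl or a plain acryloyl group on this nitrogen could separate. No evidence here explains the large step.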